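The source may hold more compounds than are shown below. What is called first, only, known or untested is meant among the compounds shown, and "the series" means these compounds.

Compound 1 `CNCCNCc1cccc(-c2nc(NC3CCOCC3)c(C)c(-c3cccc4cnccc34)n2)c1` gives 32000 nM in a functional assay on BT-549 cells (Homo sapiens) for inhibition, read by sulforhodamine B assay, with a stated time of 6 days; a lower number here means a stronger inhibitor, a higher number a weaker inhibitor. Compound 2 `CNCCNCc1cccc(-c2nc(NC3CCOCC3)c(C)c(-c3ccc(O)cc3)n2)c1` gives 23700 nM in this assay, a shift of a 1.4-fold lower number from compound 1 to compound 2 (0.13 log units; within the scatter). Going by the values given here, compound 3 `CNCCNCc1cccc(-c2nc(NC3CCOCC3)c(C)c(-c3cccnc3)n2)c1` returns only a limit in this assay, > 50000 nM, the single value at the limit of > 50000 nM in this assay, at which 1 of the 3 values shown sits. The steps reaching it are an at least 1.5-fold higher number from compound 1 to compound 3 (0.19 log units; that floor lies within the scatter) and an at least 2.1-fold higher number from compound 2 to compound 3 (0.32 log units; beyond the scatter). Compound 4 `CNCCNCc1cccc(-c2nc(Nc3ccccc3)c(C)c(-c3cccnc3)n2)c1` differs from compound 3 by phenyl in place of oxan-4-yl on a nitrogen on an aromatic ring, on the nitrogen on an aromatic ring whose other neighbours are aromatic carbon. Among the compounds with values here, none of the three measured steps touches that nitrogen; each alters the aromatic substituent instead, so no measured step sets an expectation for this assay beyond the scatter. Compound 4 is expected at 50000 nM, within 15000 nM to 150000 nM, an estimated step of a number no higher from compound 3 to compound 4 (the limit leaves the size open).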

Compound 4, half-maximal inhibitory concentration: 14100 nM
The estimate for compound 4 lay 3.5-fold (0.55 log units) above the measured number; the measured number lies below the stated range.
By their numbers in this assay, from the lowest: compounds 4, 2 and 1 (each within the scatter of the next, the first and the last beyond it). At a limit, above all of these: compound 3.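

In this assay the only change shown on the nitrogen on an aromatic ring gives an at least 3.5-fold lower number from compound 3 to compound 4 (0.54 log units; beyond the scatter) with phenyl in place of oxan-4-yl, so this position moves the number, whereas the earlier steps altered only the aromatic substituent. From the compounds shown here alone, the true size of the step stays open, since the value for compound 3 is a limit and not a number: the limit of > 50000 nM in this assay, at which 1 of the 4 values shown sits.

Going by these compounds, whether anilino gives a similar shift with 4-hydroxyphenyl or isoquinolin-5-yl in place of pyridin-3-yl remains open. So does the effect of a cyclohexyl or benzyl group on that nitrogen.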